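This account rests on a few compounds, and the source may have more. Where it says the series, first, only, none or still open, it means among the compounds named here.

Compound 1 `CCCCCCCCCCCC(=O)OC[C@H](CSC[C@@H](N)C(=O)NC(C)CCC(C)C)OC(=O)CCCCCCCCCCC` gives 190 nM in an assay on HEK293 cells for agonist activity at Toll-like receptor 2 (Homo sapiens); on this read-out higher numbers stand for an effect only at larger amounts of compound and lower numbers for an effect already at smaller amounts.
Compound 2 `CCCCCCCCCCCC(=O)OC[C@H](CSC[C@@H](N)C(=O)NC(CC)COC)OC(=O)CCCCCCCCCCC` gives 71.8 nM in this assay.
Compound 3 `CCCCCCCCCCCC(=O)OC[C@H](CSC[C@@H](N)C(=O)NCCOCCOCCOCCC(=O)O)OC(=O)CCCCCCCCCCC` gives 900 nM in this assay.

Compound 3 stands highest of the three numbers, beyond the scatter above compound 1 and further still above compound 2. All three share the same core; they differ only in the group carried on the amide-type nitrogen. Among the measured compounds shown here, the one step between compounds that differ in a single place is a 2.6-fold lower number from compound 1 to compound 2 (0.42 log units; beyond the scatter), where one small branched group was exchanged for another. Compound 3 and compound 1 are not such a pair, but their two values show that the long 2-(2-(2-carboxyethoxy)ethoxy)ethoxy chain goes with a clearly higher number than the 1,4-dimethylpentyl group.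

Compound 4 `CCCCCCCCCCCC(=O)OC[C@H](CSC[C@@H](N)C(=O)NCCCCN)OC(=O)CCCCCCCCCCC` differs from compound 3 by 2-aminoethyl in place of 2-(2-(2-carboxyethoxy)ethoxy)ethoxy on a saturated chain carbon, two bonds along the chain from an amide-type nitrogen. For the measured compounds named here, no measured step covers this change directly, so the expectation rests on the gap between compound 3 and the two compounds with small groups. Since the long chain in compound 3 goes with the highest number, trimming it back to a short 2-aminoethyl is expected to bring compound 4 toward compound 1 and compound 2. Compound 4 is therefore estimated at 220 nM in this assay, within 60 nM to 800 nM. This estimate means a step of a 4.1-fold lower number from compound 3 to compound 4 (0.61 log units; beyond the scatter).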

Compound 4, half-maximal effective concentration: 1040 nM
Compound 4: the middle estimate sits 4.7-fold (0.67 log units) below what was measured; measured number outside the range, above it.
By their numbers in this assay, from the lowest: compound 2; then compound 1; then compounds 3 and 4 (each within the scatter of the next).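

Exchanging 2-(2-(2-carboxyethoxy)ethoxy)ethoxy for 2-aminoethyl, on a saturated chain carbon, two bonds along the chain from an amide-type nitrogen, gives a 1.2-fold higher number from compound 3 to compound 4 (0.06 log units; within the scatter) in this assay and so makes no real difference, even though the group entering has far fewer heavy atoms than the group leaving. Shortening the chain is thus not enough by itself to reach the lower numbers: placing 4-aminobutyl on the amide-type nitrogen gives a 5.5-fold higher number from compound 1 to compound 4 (0.74 log units; beyond the scatter) and a 14-fold higher number from compound 2 to compound 4 (1.16 log units; beyond the scatter) when it replaces the two branched groups. Among these four compounds, the two branched groups go with lower numbers than the two unbranched chains, with no compound going against this, but nothing available here explains the difference.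

From the compounds shown here alone, what remains open is whether the higher numbers go with the unbranched chain itself or with the amine and carboxylic acid at the chain ends, as each unbranched chain here carries one of these and neither branched group does. A plain butyl chain without an amine, or a branched group ending in an amine, would separate these two readings.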